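The compounds below may be only part of what the source reports. "The series", "measured", "known", "first", "only" and "open" are said of these compounds alone.

Working notes on the series. Compound 1 `Cc1ccc2[nH]c(=O)c(/C=N/c3ccc(C(=O)O)cc3)cc2c1` is reported in a functional assay, read by spectrophotometry, with a stated time of 30 min (on this read-out higher numbers stand for weaker inhibition and lower numbers for stronger inhibition), as "not active" (no number reported), so no number stands against it; compound 1 therefore sits among the entries of this set that carry no single value. Among the measured compounds shown here, the only compound with a number is compound 2 `Cc1ccc2[nH]c(=O)c(/C=N/O)cc2c1`, which in this assay gives 160000 nM, a very weak result. Compound 3 `Cc1ccc2[nH]c(=O)c(/C=N/Nc3ccc([N+](=O)[O-])cc3[N+](=O)[O-])cc2c1` is, like compound 1, without a single number; in this assay compound 3 is reported as "not active" (no number reported). Against this background compound 1 cannot be placed above or below compound 2; it can only be said that nothing in the set so far reaches a useful level of inhibition.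

Compound 4 `Cc1ccc2[nH]c(=O)c(/C=N/c3ccc(S(N)(=O)=O)cc3)cc2c1` differs from compound 1 by sulfamoyl in place of carboxy on an aromatic carbon. For the measured compounds named here, no measured step exists for this change. Given that compound 1 shows "not active" (no number reported) and compound 2 shows 160000 nM, no step beyond the scatter is expected in this assay from compound 1 to compound 4; the most likely outcome is that compound 4 also returns no number. Should a value appear, compound 4 is estimated at 300000 nM, in a range of 80000 nM to 1500000 nM.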

Compound 4, half-maximal inhibitory concentration: "not active" (no number reported)
No number was reported for compound 4; the estimate stays without a comparison.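

In this assay compound 1 and compound 4 both carry no number, so no step can be read for sulfamoyl in place of carboxy. The compounds shown leave open whether this exchange alters inhibition at all. No measured evidence bears on this result.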